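Changing the outer aryl group of a thromboxane receptor antagonist

The compounds below may be only part of what the source reports. "The series", "measured", "known", "first", "only" and "open" are said of these compounds alone.

Three compounds share one core and differ at a single aromatic carbon. Compound 1 `O=C(O)CC/C=C\CO[C@H]1C(OCc2ccc(-c3ccccc3)cc2)CC[C@@H]1N1CCCCCC1` gives 25.1 nM in a functional assay for antagonist activity at thromboxane A2 receptor (Rattus norvegicus); on this read-out lower numbers stand for tighter binding and higher numbers for weaker binding. Compound 2 `NC(=O)c1ccccc1-c1ccc(COC2CC[C@H](N3CCCCCC3)[C@H]2OC/C=C\CCC(=O)O)cc1` gives 15.9 nM in this assay, and compound 3 `CS(=O)(=O)Nc1cccc(-c2ccc(COC3CC[C@H](N4CCCCCC4)[C@H]3OC/C=C\CCC(=O)O)cc2)c1` gives 50.1 nM in this assay, the highest number of the three. The step of a 1.6-fold lower number from compound 1 to compound 2 (0.20 log units; within the scatter) and the step of a 2.0-fold higher number from compound 1 to compound 3 (0.30 log units; within the scatter) both stay inside the scatter, while the step of a 3.2-fold higher number from compound 2 to compound 3 (0.50 log units; beyond the scatter) is modest but real.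

Compound 4 `CC(=O)NCc1ccc(-c2ccc(COC3CC[C@H](N4CCCCCC4)[C@H]3OC/C=C\CCC(=O)O)cc2)cc1` carries 4-(acetamidomethyl)phenyl in place of 3-(methanesulfonamido)phenyl on an aromatic carbon. Among the measured compounds shown here, no measured step adds or removes this group, so the expectation rests on how little the three measured groups moved the numbers: every step seen here is small, at most modest. The new group is therefore expected to land near the other three, which means a small step of a 2.0-fold lower number from compound 3 to compound 4 (0.30 log units; within the scatter) toward lower numbers from compound 3 to compound 4 is expected, and no more. Compound 4 is estimated at 25 nM, with a plausible range from 8 nM to 80 nM in this assay.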

Compound 4, dissociation constant: 20 nM
Compound 4: the middle estimate sits 1.3-fold (0.10 log units) above what was measured, within the range that was stated.
By their numbers in this assay, from the lowest: compounds 2, 4, 1 and 3 (each within the scatter of the next, the first and the last beyond it).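

Replacing 3-(methanesulfonamido)phenyl with 4-(acetamidomethyl)phenyl gives a 2.5-fold lower number from compound 3 to compound 4 (0.40 log units; beyond the scatter) in this assay and so shows that this position can tell apart two groups that each hold 11 heavy atoms and one six-membered aromatic ring. Group size, counted this way, therefore does not settle the number for this pair. The acetamidomethyl group is also tolerated here, since a 1.3-fold lower number from compound 1 to compound 4 (0.10 log units; within the scatter) and a 1.3-fold higher number from compound 2 to compound 4 (0.10 log units; within the scatter) both stay small.

Nothing available explains the difference between compound 3 and compound 4. The two groups differ in both identity and place on the ring, so 4-(methanesulfonamido)phenyl and 3-(acetamidomethyl)phenyl would be needed to separate those changes, and an aminomethyl group or a carboxylic acid at this position remains an open case.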